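A few compounds are considered here, and "the series" means these few. Any claim that something is new, unique, unknown or untested is made for them only; others in the source may bear on it.

Measured in a functional assay on A549 cells (Homo sapiens) for cytotoxicity, read by MTT assay, with a stated time of 72 h; on this read-out lower numbers stand for stronger inhibition and higher numbers for weaker inhibition:

- compound 1 `Cc1oc2ncnc(Nc3cccc(Br)c3)c2c1C(=O)O`: 43000 nM
- compound 2 `Cc1cccc(Nc2ncnc3oc(C)c(CO)c23)c1`: 24000 nM
- compound 3 `CCOC(=O)c1c(C)oc2ncnc(Nc3ccc(OCc4cccc(Cl)c4)cc3)c12`: 513000 nM

The value of compound 1 lies within the usual scatter of the value of compound 2, so these two cannot be ranked against each other. The number for compound 3 is clearly higher than both, well beyond the scatter.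

The next molecule is compound 4 `CCOC(=O)c1c(C)oc2ncnc(Nc3cccc(Br)c3)c12`, which is made from compound 1 by one change: ethyl in place of hydrogen on an oxygen next to a carbonyl group. In other words, ethyl takes the place of hydrogen on an oxygen next to a carbonyl group, turning carboxy into ethoxycarbonyl.

Within the data shown here, no measured pair here shows this change on its own, so any forecast rests on thin evidence. Compound 3 also carries ethoxycarbonyl and gives 513000 nM, but it differs from compound 4 elsewhere as well, so this value is only a weak guide. The starting point remains compound 1 at 43000 nM, and no shift beyond the scatter is expected in this assay. The expected change is a 1.4-fold lower number from compound 1 to compound 4 (0.16 log units; within the scatter). For compound 4 the estimated value is 30000 nM, with an expected range of 8000 nM to 110000 nM.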

Compound 4, half-maximal inhibitory concentration: > 1000000 nM
Compound 4: a limit, no number; the forecaster's own chance of this, stated with the estimate: 5%; at least 33-fold (1.52 log units) between middle value and limit.
By their numbers in this assay, from the lowest: compounds 2 and 1 (each within the scatter of the next); then compound 3. At a limit, above all of these: compound 4.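

At this place, on an oxygen next to a carbonyl group, turning carboxy into ethoxycarbonyl has a large effect in this assay: putting ethyl in place of hydrogen gives an at least 23-fold higher number from compound 1 to compound 4 (1.36 log units; beyond the scatter). Compound 4 reads > 1000000 nM, which is a limit of the assay and not a number. Ethoxycarbonyl appeared earlier only in compound 3, which differs from compound 1 in more than one place, so this pair is the first to show the change on its own, but the full size of the step cannot be read from a limit: the limit of > 1000000 nM in this assay, at which 1 of the 4 values shown sits.

The compounds shown do not separate the effect of adding ethyl from the effect of removing the hydrogen of carboxy, and a methyl ester or a primary amide at this place would help to tell the two apart. As far as these compounds go, it also remains open whether the same change would have a similar effect on compounds with a different group on the nitrogen-linked ring, as the pair here shares the bromine-bearing ring of compound 1.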